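The compounds below may be only part of what the source reports. "The series", "measured", "known", "first", "only" and "open" are said of these compounds alone.

Measured so far:
compound 1 `CC(Sc1nc2c(cnn2C)c(=O)n1-c1ccccc1)c1cccc(F)c1`: 0.133 h
compound 2 `Cn1ncc2c(=O)n(-c3ccccc3)c(SCc3cccc(F)c3)cc21`: 0.15 h

In an ADME assay on microsomes from liver (Mus musculus, strain CD-1) for metabolic stability, read by LC-MS, with a stated time of 60 min, tested at 20 uM (a higher number here means that the compound lasts longer, a lower number that the compound disappears faster), compound 1 gives 0.133 h and compound 2 gives 0.15 h; the gap between them lies within the scatter, so the two are not separated. Compound 3 `C[C@@H](Sc1nc2c(cnn2C)c(=O)n1-c1ccccc1)c1ccccc1` is not yet measured. Compared with compound 1 it shows (1-phenylethyl in place of 1-(3-fluorophenyl)ethyl on a sulfur). Going by the values given here, no measured pair shows a step of this kind, so its size cannot be read from the data. The expected step in this assay is a 1.1-fold lower number from compound 1 to compound 3 (0.04 log units; within the scatter), not beyond the scatter in either direction. For compound 3 the estimated value in this assay is 0.12 h, with a range of 0.06 h to 0.24 h.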

Compound 3, half-life: 0.133 h
The estimate for compound 3 lay 1.1-fold (0.04 log units) below the measured number, and the stated range covers the measured number.
By their numbers in this assay, from the lowest: compounds 1, 3 and 2 (each within the scatter of the next).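

In this assay, 1-phenylethyl in place of 1-(3-fluorophenyl)ethyl on a sulfur gives no change at the digits printed from compound 1 to compound 3 (within the scatter). Going by these compounds alone, this is the first readable step at this position: the fluorine does not separate the two compounds here, although compound 3 also carries a defined stereocentre, so the step covers both differences. No measured evidence bears on this result.

Still open, as far as these compounds go, is whether an amine or a carboxylic acid in place of 1-phenylethyl on a sulfur would move the number. From the compounds shown here alone, how the opposite stereocentre would read also remains open.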